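The compounds below may be only part of what the source reports. "The series", "measured", "known", "first", "only" and "open" are said of these compounds alone.

Measured so far in an assay for inhibition of Catechol O-methyltransferase (Rattus norvegicus), read by fluorescence and spectrophotometry; a higher number here means a weaker inhibitor, a lower number a stronger inhibitor:
compound 1 `CC(=O)N1N=C(c2cc(O)c(O)c([N+](=O)[O-])c2)CC1c1ccco1` gives 180 nM;
compound 2 `CC(=O)N1N=C(c2cc(O)c(O)c([N+](=O)[O-])c2)CC1c1nccs1` gives 160 nM;
compound 3 `CC(=O)N1N=C(c2cc(O)c(O)c([N+](=O)[O-])c2)CC1c1ccoc1` gives 180 nM.

Compound 3 stands level with compound 1 at the digits shown, the two together being the highest of the three numbers; compound 1 is nearest, with no change at the digits printed from compound 1 to compound 3 (within the scatter), and compound 2 furthest, with a 1.1-fold higher number from compound 2 to compound 3 (0.05 log units; within the scatter). Compound 4 `CC(=O)N1N=C(c2cc(O)c(O)c([N+](=O)[O-])c2)CC1c1cccs1` carries the change (thiophen-2-yl in place of furan-3-yl on a saturated ring carbon). Going by the values given here, two measured steps bear on it: the swap of one five-membered heteroaryl for another in a 1.1-fold lower number from compound 1 to compound 2 (0.05 log units; within the scatter), and the shift of attachment point within the same heteroaryl in no change at the digits printed from compound 1 to compound 3 (within the scatter), both within the scatter. The expected step is therefore a 1.1-fold lower number from compound 3 to compound 4 (0.02 log units; within the scatter), none beyond the scatter. For compound 4 the estimate in this assay is 170 nM, between 90 nM and 340 nM.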

Compound 4, half-maximal inhibitory concentration: 210 nM
Compound 4: middle estimate off by 1.2-fold (0.09 log units), on the low side; measured number inside the range.
By their numbers in this assay, from the lowest: compounds 2, 1, 3 and 4 (each within the scatter of the next).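

In this assay, thiophen-2-yl on this saturated ring carbon stays within the scatter of all three earlier groups (a 1.2-fold higher number from compound 3 to compound 4 (0.07 log units; within the scatter); a 1.2-fold higher number from compound 1 to compound 4 (0.07 log units; within the scatter); a 1.3-fold higher number from compound 2 to compound 4 (0.12 log units; within the scatter)). Sulfur in place of oxygen in a five-membered aromatic ring with 1 hetero atom therefore gives no readable step, and four such rings now sit within the scatter at this position. No supporting data bear on why this is so.

As far as these compounds go, whether a phenyl ring, a piperidine amine, a carboxylic acid or a longer alkyl chain at this carbon would move the number beyond the scatter stays open. So does whether the same holds with the acetyl group replaced.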